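Amide Substituent Size and Antiproliferative Inhibition

The compounds below may be only part of what the source reports. "The series", "measured", "known", "first", "only" and "open" are said of these compounds alone.

Measured compounds:
compound 1 `CCC(=O)Nc1cc(Oc2ccc(Nc3nccc4[nH]cc(-c5ccc(F)cc5)c(=O)c34)cc2F)ccn1` gives 68.7%
compound 2 `CC(C)(C)C(=O)Nc1cc(Oc2ccc(Nc3nccc4[nH]cc(-c5ccc(F)cc5)c(=O)c34)cc2F)ccn1` gives -45.8%
compound 3 `O=C(Nc1cc(Oc2ccc(Nc3nccc4[nH]cc(-c5ccc(F)cc5)c(=O)c34)cc2F)ccn1)C1CC1` gives 25.5%

In a functional assay on HT-29 cells (Homo sapiens) for antiproliferative activity, read by MTT assay, with a stated time of 72 h, tested at 10 uM (on this read-out higher numbers stand for more inhibition at the one concentration tested (going by the name of the read-out) and lower numbers for less inhibition), compound 1 stands highest of the three measured compounds, with compound 3 nearest and compound 2 furthest below it. Compound 4 `O=C(Nc1cc(Oc2ccc(Nc3nccc4[nH]cc(-c5ccc(F)cc5)c(=O)c34)cc2F)ccn1)C1CCC1` differs from compound 1 in one place: cyclobutyl in place of ethyl on a carbonyl carbon. Going by the values given here, two measured steps bear on this change, a number 114.5 percentage points lower from compound 1 to compound 2 (beyond the scatter) and a number 43.2 percentage points lower from compound 1 to compound 3 (beyond the scatter), both large losses beyond the scatter when another group replaces ethyl on the carbonyl carbon. Cyclobutyl is a ring larger than cyclopropyl, so a drop at least as large as that of compound 3 is expected, with a number 58.7 percentage points lower from compound 1 to compound 4 (beyond the scatter). Compound 4 is therefore estimated at 10%, within the range -40% to 50%.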

Compound 4, a percentage reported as inhibition, at one concentration (the size of the read-out at that concentration, not a potency): 46%
The estimate for compound 4 lay 36 percentage points below the measured number; low and high end bracket the measured number.
By their numbers in this assay, from the lowest: compound 2; then compound 3; then compound 4; then compound 1.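

In this assay, a ring on the carbonyl carbon need not cost much: the loss with cyclobutyl is modest, a number 22.7 percentage points lower from compound 1 to compound 4 (beyond the scatter). Inhibition also does not fall as the ring grows, with a number 20.5 percentage points higher from compound 3 to compound 4 (beyond the scatter), and cyclobutyl stands far clear of tert-butyl, with a number 91.8 percentage points higher from compound 2 to compound 4 (beyond the scatter). Nothing available explains this order.

From the compounds shown here alone, whether a cyclopentyl ring, a longer chain such as butyl, or an amine on the carbonyl carbon would keep this inhibition remains open. So does whether any ring can match the ethyl group of compound 1.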